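A few compounds are considered here, and "the series" means these few. Any claim that something is new, unique, unknown or untested is made for them only; others in the source may bear on it.

Measured compounds:
- compound 1 `O=C(c1cccc(Cl)c1)N1CCC(NS(=O)(=O)c2cc(S(=O)(=O)c3ccccc3)ccc2C(F)(F)F)CC1`: 6300 nM
- compound 2 `CN(C)c1ccc(C(=O)N2CCC(NS(=O)(=O)c3cc(S(=O)(=O)c4ccccc4)ccc3C(F)(F)F)CC2)cc1`: 50000 nM

In a physicochemical assay for solubility (a lower number here means a less soluble compound, a higher number a more soluble compound), compound 2 has the higher number of the two, at 50000 nM. The next compound, compound 3 `CN(C)c1ccc(C(=O)N2CCC(NS(=O)(=O)c3cc(S(=O)(=O)c4ccccc4)ccc3C(F)(F)F)CC2)cn1`, has not yet been measured. It carries 6-(dimethylamino)pyridin-3-yl in place of 4-(dimethylamino)phenyl on a carbonyl carbon. Among the measured compounds shown here, one measured step bears on this place, a 7.9-fold higher number from compound 1 to compound 2 (0.90 log units; beyond the scatter). That step is modest but exchanged a different pair of groups, so it shows that changes here can register without giving a size for this exchange. The new change keeps the dimethylamino group and alters only the aromatic ring, so no shift beyond the scatter is expected in this assay. The expected step is a 1.2-fold higher number from compound 2 to compound 3 (0.08 log units; within the scatter). Compound 3 is estimated at 60000 nM, with an expected range of 25000 nM to 140000 nM.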

Compound 3, solubility: 12500 nM
Estimate against measurement, compound 3: 4.8-fold (0.68 log units) above; the measured number lies below the stated range.
By their numbers in this assay, from the lowest: compounds 1 and 3 (each within the scatter of the next); then compound 2.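

In this assay the exchange of 4-(dimethylamino)phenyl for 6-(dimethylamino)pyridin-3-yl on a carbonyl carbon, with the dimethylamino group kept, gives a 4.0-fold lower number from compound 2 to compound 3 (0.60 log units; beyond the scatter) and so shows that this position registers a change in the aromatic ring itself, not only a change of the whole group. Set against the 3-chlorophenyl group, 6-(dimethylamino)pyridin-3-yl gives a 2.0-fold higher number from compound 1 to compound 3 (0.30 log units; within the scatter) and so the two compounds carrying the dimethylamino group do not read alike in this assay. Nothing measured here accounts for the difference between the two rings.

On these data alone, whether a morpholine or a pyrrolidine in place of the dimethylamino group on the pyridine ring would read like compound 3 remains open. So does the reading for a pyrimidine ring in place of the pyridine ring at this same place.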